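The source may report more compounds than this note shows. Statements on the series, on what has been measured and on what is new or still open speak of the compounds shown alone.

Compound 1 `CN(C)C(=O)C[C@@H]1CN[C@H](C(=O)N2CCC[C@H]2C#N)C1` and compound 2 `C[C@@H]1N[C@H](C(=O)N2CCC[C@H]2C#N)C[C@@H]1C(=O)N1CCCC1` were both examined in an assay on the whole organism (plasma, strain Sprague-Dawley) for inhibition of Dipeptidyl peptidase 4 (Rattus norvegicus), with a stated time of 6 h, at a dose of 1 mg/kg by the oral route; on this read-out higher numbers stand for more inhibition at the one dose given (going by the name of the read-out) and lower numbers for less inhibition. In this assay compound 1 gives 66%, while compound 2 gives 94%; compound 1 therefore stands lowest of the two numbers, and the gap to compound 2 lies beyond the usual scatter of such measurements. Compound 3 `N#C[C@@H]1CCCN1C(=O)[C@@H]1CCCN1` keeps the shared core but differs from compound 1 in one place: hydrogen in place of (dimethylcarbamoyl)methyl on a saturated ring carbon. Within the data shown here, with only two measured compounds and no change of this kind yet measured, the size of the step can only be judged from what remains once this group is gone. Compound 3 is expected to give a lower number, with an estimated step of a number 21 percentage points lower from compound 1 to compound 3 (beyond the scatter). On that basis compound 3 is estimated at 45%, with a range from 15% to 75%.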

Compound 3, a percentage reported as inhibition, in the whole organism at one dose (the size of the read-out at that dose, not a potency): 20%
Compound 3: the middle estimate sits 25 percentage points above what was measured; the measured number falls inside the stated range.
By their numbers in this assay, from the lowest: compound 3; then compound 1; then compound 2.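

Taking (dimethylcarbamoyl)methyl off the saturated ring carbon gives the first reading of a change at this position in this assay, and it comes to a number 46 percentage points lower from compound 1 to compound 3 (beyond the scatter). The number at this one dose thus depends strongly on whether this ring carbon bears that group or hydrogen, and compound 3, with hydrogen there, gives 20%. Nothing at hand bears on the reason for this fall.

The compounds shown leave open which part of the group matters: the carbonyl, the dimethylamino end or the chain alone. From the compounds shown here alone, a methyl, a carboxylic acid or a primary amine on the same ring carbon would begin to separate these, and it also remains open whether the same step would appear at another dose or time.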